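Swapping the para group on the sulfonyl ring: cyano to acetamido

This account rests on a few compounds, and the source may have more. Where it says the series, first, only, none or still open, it means among the compounds named here.

Measured compounds in a functional assay on HepG2 cells (Homo sapiens) for cytotoxicity, read by MTT assay, with a stated time of 24 h; on this read-out higher numbers stand for weaker inhibition and lower numbers for stronger inhibition:
Compound 1, `O=C1/C(=C/c2cccc(F)c2)CN(S(=O)(=O)c2ccc(O[N+](=O)[O-])cc2)C/C1=C\c1cccc(F)c1`, gives 8100 nM.
Compound 2, `O=C1/C(=C/c2cccc(F)c2)CN(S(=O)(=O)c2ccc(F)cc2)C/C1=C\c1cccc(F)c1`, gives 5000 nM.
Compound 3, `N#Cc1ccc(S(=O)(=O)N2C/C(=C\c3cccc(F)c3)C(=O)/C(=C/c3cccc(F)c3)C2)cc1`, gives 2600 nM.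

Compound 3 has the lowest number of the three, though its gap to compound 2 is within the scatter and only its gap to compound 1 is beyond it. Compound 4, `CC(=O)Nc1ccc(S(=O)(=O)N2C/C(=C\c3cccc(F)c3)C(=O)/C(=C/c3cccc(F)c3)C2)cc1`, differs from compound 3 by acetamido in place of cyano on an aromatic carbon. Among the compounds with values here, the steps that bear on this are the earlier para swaps on the same ring: a 1.6-fold lower number from compound 1 to compound 2 (0.21 log units; within the scatter), a 3.1-fold lower number from compound 1 to compound 3 (0.49 log units; beyond the scatter) and a 1.9-fold lower number from compound 2 to compound 3 (0.28 log units; within the scatter). All stayed modest, so a small step is expected here too, if anything toward a higher number: a 1.5-fold higher number from compound 3 to compound 4 (0.19 log units; within the scatter) is the expected step. Compound 4 is therefore estimated at 4000 nM, with a range from 1500 nM to 11000 nM.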

Compound 4, half-maximal inhibitory concentration: 11100 nM
Compound 4: the middle estimate sits 2.8-fold (0.44 log units) below what was measured; the measured number lies above the stated range.
By their numbers in this assay, from the lowest: compounds 3, 2, 1 and 4 (each within the scatter of the next, the first and the last beyond it).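

In this assay, the number at this position can move further than the earlier swaps showed: acetamido, which brings a hydrogen-bond donor that cyano lacks, gives a 4.3-fold higher number from compound 3 to compound 4 (0.63 log units; beyond the scatter), the largest step here so far, and a 2.2-fold higher number from compound 2 to compound 4 (0.35 log units; beyond the scatter). Against nitrooxy it gives a 1.4-fold higher number from compound 1 to compound 4 (0.14 log units; within the scatter), so those two groups cannot be told apart. No measurement here accounts for these differences.

On these data alone, whether the amide hydrogen matters remains open, as does where a plain amine or a carboxylic acid on this carbon would fall.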